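A few compounds are considered here, and "the series" means these few. Any claim that something is new, unique, unknown or untested is made for them only; others in the source may bear on it.

Compound 1 `O=C(NC(=S)Nc1cccc(-c2nc3ccccc3[nH]2)c1)c1ccccc1` is an acylthiourea built on the shared core. In a functional assay on HUVEC cells (Homo sapiens) for inhibition, read by colorimetric assay and crystal violet staining, with a stated time of 72 h (a higher number here means a weaker inhibitor, a lower number a stronger inhibitor), compound 1 gives > 10000 nM, which is a limit of the assay rather than a number (the limit of > 10000 nM in this assay, at which 1 of the 3 values shown sits). Two measured companions alter only the ring on the carbonyl carbon. Compound 2 `O=C(NC(=S)Nc1cccc(-c2nc3ccccc3[nH]2)c1)c1ccc2c(c1)OCCO2` gives < 100 nM in this assay, again a limit of the assay and not a number (the limit of < 100 nM in this assay, at which 1 of the 3 values shown sits). Compound 3 `COc1ccc(C(=O)NC(=S)Nc2cccc(-c3nc4ccccc4[nH]3)c2)cc1OC` gives 5000 nM in this assay. The step of an at least 100-fold lower number from compound 1 to compound 2 (2.00 log units; beyond the scatter) is large, whereas an at least 2.0-fold lower number from compound 1 to compound 3 (0.30 log units; that floor lies within the scatter) stays within the usual scatter of such measurements, and an at least 50-fold higher number from compound 2 to compound 3 (1.69 log units; beyond the scatter) is again large.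

Compound 4 `Cc1ccc(-c2nc3ccccc3[nH]2)cc1NC(=S)NC(=O)c1ccccc1` differs from compound 1 in a different place: methyl in place of hydrogen on an aromatic carbon. Within the data shown here, none of the measured steps touches this position; all three concern the ring on the carbonyl carbon, so they give no direct guide to the size or direction of this particular change. Since compound 1 sits at a limit, the step of a number no higher from compound 1 to compound 4 (the limit leaves the size open) is expected to be small. Compound 4 is therefore expected to give 10000 nM in this assay, with a range from 2000 nM to 50000 nM, and quite possibly only a limit again.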

Compound 4, half-maximal inhibitory concentration: > 10000 nM
Compound 4 ended at the assay's limit (the forecaster's own chance of this, stated with the estimate: 60%); the middle value lies on the limit itself.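

Compound 1 and compound 4 both stop at the same limit in this assay, so the step between them cannot be read: the limit of > 10000 nM in this assay, at which 2 of the 4 values shown sit.

The compounds shown leave open whether methyl in place of hydrogen on this aromatic carbon changes the inhibition at all, and what it would do alongside the 2,3-dihydro-1,4-benzodioxin-6-yl group of compound 2.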